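From a six-membered ring to cyclobutylmethoxy

The compounds below may be only part of what the source reports. "The series", "measured", "known", "first", "only" and "open" are said of these compounds alone.

Within the data shown here, in a physicochemical assay for solubility (a higher number here means a more soluble compound, a lower number a less soluble compound), compound 1 `C[C@@H]1CN(c2cc(C(F)(F)F)nn2-c2ccc(S(C)(=O)=O)cn2)[C@H](C)CO1` gives 100 ug/mL as the only plain number available. Compound 2 `C[C@@H]1CN(c2c(C#N)c(C(F)(F)F)nn2-c2ccc(S(C)(=O)=O)cn2)[C@H](C)CO1` stands at > 200 ug/mL which is a limit of the assay and not a number. For compound 3 `CC1CCCN(c2c(C#N)c(C(F)(F)F)nn2-c2ccc(S(C)(=O)=O)cc2)C1` the entry reads "not determined" (no result reported) and offers nothing to compare.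

Compound 4 `CS(=O)(=O)c1ccc(-n2nc(C(F)(F)F)cc2OCC2CCC2)nc1` keeps the core of compound 1 and exchanges one group on it (a group of 6 heavy atoms (5 carbon, 1 oxygen; one four-membered non-aromatic ring of carbon only) in place of a group of 8 heavy atoms (6 carbon, 1 nitrogen, 1 oxygen; one six-membered non-aromatic ring with 2 hetero atoms), on an aromatic carbon). Among the measured compounds shown here, the one measured step (an at least 2.0-fold higher number from compound 1 to compound 2 (0.30 log units; that floor lies within the scatter)) puts cyano in place of hydrogen on an aromatic carbon. That is a different change from this one, and its floor lies within the scatter. For the measured compounds named here, no measured step touches the group that leaves or the cyclobutylmethoxy that enters, so the guidance is thin. A modest fall is the cautious expectation, and it could well prove wrong. The estimated step (a 2.5-fold lower number from compound 1 to compound 4 (0.40 log units; beyond the scatter)) is therefore expected to be downward in this assay but uncertain in size. For compound 4 the estimate is 40 ug/mL with an expected range from 10 ug/mL to 150 ug/mL for this measurement.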

Compound 4, solubility: 100 ug/mL
The estimate for compound 4 lay 2.5-fold (0.40 log units) below the measured number, within the range that was stated.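

In this assay, the exchange gives no change at the digits printed from compound 1 to compound 4 (within the scatter). Among these compounds, this is the first measured step at this place, on an aromatic carbon next to the ring nitrogen, and it shows that the number can hold when the ring with 2 hetero atoms and 2 defined stereocentres gives way to cyclobutylmethoxy, which has a four-membered ring of carbon only. This single pair cannot say which part of the exchange matters, and it makes no rule for other groups.

Still open, from the compounds shown here alone, is whether an amine such as dimethylamino, or a longer chain such as butoxy, would read the same at this place, and whether adding a nitrile to compound 4 would shift its number. Compound 2, the only compound with a nitrile and a result, stands at a limit of the assay and not at a number: the limit of > 200 ug/mL in this assay, at which 1 of the 4 values shown sits.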